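One Fluorophenyl for Another at the Carbonyl

A few compounds are considered here, and "the series" means these few. Any claim that something is new, unique, unknown or untested is made for them only; others in the source may bear on it.

Of the compounds shown here, three built on one shared core have been tested in a functional assay on A549 cells (Homo sapiens) for inhibition, read by MTT assay, with a stated time of 72 h; a higher number here means a weaker inhibitor, a lower number a stronger inhibitor. Compound 1 `CN(C(=O)NC(=O)c1cccc(C(F)(F)F)c1)c1nc(C(F)(F)F)c(C(=O)N/N=C/c2cccc(C(F)(F)F)c2)s1` gives 8.16 ug/mL. Compound 2 `CN(C(=O)NC(=O)c1ccccc1F)c1nc(C(F)(F)F)c(C(=O)N/N=C/c2ccccc2C(F)(F)F)s1` gives 6.32 ug/mL. Compound 3 `CN(C(=O)NC(=O)c1ccc(F)c(F)c1)c1nc(C(F)(F)F)c(C(=O)N/N=C/c2cccc(C(F)(F)F)c2)s1` gives 6.52 ug/mL. Compound 3 stands second highest of the three numbers; the value closest to it belongs to compound 2 and the furthest to compound 1, yet both gaps fall within the scatter of repeated measurements, so the three compounds cannot be told apart on these numbers.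

Compound 4 `CN(C(=O)NC(=O)c1ccccc1F)c1nc(C(F)(F)F)c(C(=O)N/N=C/c2cccc(C(F)(F)F)c2)s1` has not yet been measured. It differs from compound 3 in one place: 2-fluorophenyl in place of 3,4-difluorophenyl on a carbonyl carbon. Among the measured compounds shown here, one measured step concerns the same carbonyl carbon: a 1.3-fold lower number from compound 1 to compound 3 (0.10 log units; within the scatter), a step within the scatter. For the measured compounds named here, compound 2 carries the same 2-fluorophenyl group that enters in compound 4, but it also differs from compound 4 elsewhere, so no single-change step joins them; its value and that of compound 3 lie within the scatter of each other. Going by the values given here, with the only comparable step being flat, no shift beyond the scatter is expected for compound 4 in this assay: a 1.0-fold lower number from compound 3 to compound 4 (0.01 log units; within the scatter). Compound 4 is therefore estimated at 6.4 ug/mL, with a range from 3.5 ug/mL to 12 ug/mL.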

Compound 4, half-maximal inhibitory concentration: 19.5 ug/mL
Beside the measured number, compound 4's estimate is 3.0-fold (0.48 log units) below it; measured number outside the range, above it.
By their numbers in this assay, from the lowest: compounds 2, 3 and 1 (each within the scatter of the next); then compound 4.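

In this assay, the carbonyl carbon no longer looks indifferent to its aryl group: swapping 3,4-difluorophenyl for 2-fluorophenyl gives a 3.0-fold higher number from compound 3 to compound 4 (0.48 log units; beyond the scatter) and swapping 3-(trifluoromethyl)phenyl for 2-fluorophenyl gives a 2.4-fold higher number from compound 1 to compound 4 (0.38 log units; beyond the scatter) even though the two departing groups had differed only by a 1.3-fold lower number from compound 1 to compound 3 (0.10 log units; within the scatter) and could not be told apart. With 2-fluorophenyl held in place, the far end of the molecule also counts, since 3-(trifluoromethyl)phenyl in place of 2-(trifluoromethyl)phenyl on a carbon with a double bond to nitrogen gives a 3.1-fold higher number from compound 2 to compound 4 (0.49 log units; beyond the scatter) and so a single change at either site can move the number beyond the scatter. Nothing available explains why either change raises the number.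

As far as these compounds go, it remains open whether a plain phenyl ring or a pyridine ring on this carbonyl carbon would give a number like that of compound 3 or like that of compound 4. One cell line also cannot show whether these steps would hold on other cells.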